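This account rests on a few compounds, and the source may have more. Where it says the series, first, only, none or still open, it means among the compounds named here.

Measured compounds and their values:

Compound 1, `O=S(=O)(Nc1ccc(Cl)c(Cl)c1)c1ccc(-c2cnc(C3CC3)o2)cc1`: > 100000 nM, a limit of the assay.
Compound 2, `Cc1cc(NS(=O)(=O)c2ccc(-c3cnc(C4CC4)o3)cc2)ccc1Cl`: > 100000 nM, a limit of the assay.
Compound 3, `Cc1ccc(NS(=O)(=O)c2ccc(-c3cnc(C4CC4)o3)cc2)cc1C`: > 100000 nM, a limit of the assay.

In a functional assay on cells (leukaemia cell line, Homo sapiens) for inhibition, read by sulforhodamine B assay, with a stated time of 48 h (on this read-out higher numbers stand for lower toxicity in this test and lower numbers for higher toxicity in this test), compound 3 gives > 100000 nM, which is a limit of the assay and not a measured number. Among the compounds with values here, compound 1 and compound 2 sit at the same limit, so that every value so far is a limit (the limit of > 100000 nM in this assay, at which 3 of the 3 values shown sit). The steps between them, a step that the two limits leave unreadable from compound 1 to compound 2, a step that the two limits leave unreadable from compound 1 to compound 3 and a step that the two limits leave unreadable from compound 2 to compound 3, therefore cannot be sized: exchanging chloro for methyl on the aromatic ring, once or twice, left each compound beyond the range of this assay.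

Compound 4, `Cc1cc(Cl)cc(NS(=O)(=O)c2ccc(-c3cnc(C4CC4)o3)cc2)c1`, differs from compound 3 in one place: 3-chloro-5-methylphenyl in place of 3,4-dimethylphenyl on a sulfonamide nitrogen. This is again an exchange among chloro and methyl groups on the same aromatic ring, the kind of change that gave no readable step among compound 1, compound 2 and compound 3. Within the data shown here, no step in this assay is expected, so a step that the limit leaves unreadable from compound 3 to compound 4 is the estimated change. Compound 4 is expected to give about 150000 nM, in the range from 50000 nM to 500000 nM, most likely again as a limit.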

Compound 4, concentration lethal to 50% of the cells: 84900 nM
Compound 4: middle estimate off by 1.8-fold (0.25 log units), on the high side; the measured number falls inside the stated range.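

In this assay, within the data shown here, compound 4 gives 84900 nM, the first real number in this set, so a 3-chloro-5-methylphenyl on the sulfonamide nitrogen brings the series within the range of the test. The result can be read only as a floor against each of the other compounds: an at least 1.1-fold lower number from compound 3 to compound 4 (0.07 log units; that floor lies within the scatter), an at least 1.1-fold lower number from compound 2 to compound 4 (0.07 log units; that floor lies within the scatter) and an at least 1.1-fold lower number from compound 1 to compound 4 (0.07 log units; that floor lies within the scatter); the true gaps could be small or much larger. With a single measured number, this marks a starting point and not a trend: the limit of > 100000 nM in this assay, at which 3 of the 4 values shown sit.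

The compounds shown leave open how far compound 1, compound 2 and compound 3 lie beyond their limits. They also leave open how the number would respond to a different group on this ring, such as a methoxy, an amine or a carboxylic acid.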